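From furan-3-yl to thiophen-2-yl on a growth-inhibiting compound

The source may hold more compounds than are shown below. What is called first, only, known or untested is meant among the compounds shown, and "the series" means these compounds.

- compound 1 `c1ccc(-c2cc(-c3ccccn3)nc(-c3ccccn3)c2)cc1`: 0.017 ug/mL
- compound 2 `c1ccc(-c2cc(-c3ccoc3)cc(-c3ccccn3)n2)nc1`: 0.0044 ug/mL

In a functional assay on PC-3 cells (Homo sapiens) for antiproliferative activity (on this read-out higher numbers stand for weaker inhibition of growth and lower numbers for stronger inhibition of growth), compound 2 has the lower of the two numbers, 0.0044 ug/mL. Compound 3 `c1ccc(-c2cc(-c3cccs3)cc(-c3ccccn3)n2)nc1` carries thiophen-2-yl in place of furan-3-yl on an aromatic carbon. Among the measured compounds shown here, only one measured step bears on this, a 3.9-fold lower number from compound 1 to compound 2 (0.59 log units; beyond the scatter), a modest one that brought in furan-3-yl in place of phenyl. For the measured compounds named here, no thiophen-2-yl compound has been measured yet. Both groups are five-membered aromatic rings with 1 hetero atom, so only a small rise is expected in this assay, not one beyond the scatter: the expected step is a 1.5-fold higher number from compound 2 to compound 3 (0.17 log units; within the scatter). For compound 3 the estimated value is 0.0065 ug/mL, with an expected range of 0.002 ug/mL to 0.02 ug/mL.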

Compound 3, concentration for 50% growth inhibition: 0.0021 ug/mL
Beside the measured number, compound 3's estimate is 3.1-fold (0.49 log units) above it, and the stated range covers the measured number.
By their numbers in this assay, from the lowest: compound 3; then compound 2; then compound 1.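

In this assay, exchanging one five-membered aromatic ring for another at this position, opposite the ring nitrogen, still shifts the read-out: a 2.1-fold lower number from compound 2 to compound 3 (0.32 log units; beyond the scatter). The position therefore distinguishes thiophen-2-yl from furan-3-yl, and the change from the original phenyl group grows to an 8.1-fold lower number from compound 1 to compound 3 (0.91 log units; beyond the scatter). No evidence here explains why thiophen-2-yl gives the lowest number.

This step changes both the ring's hetero atom and its point of attachment, so the two effects cannot be separated. Furan-2-yl and thiophen-3-yl would pull them apart, while an amine on the thiophene ring remains open.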